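The source may hold more compounds than are shown below. What is called first, only, known or untested is meant among the compounds shown, and "the series" means these compounds.

Working notes on the series. In an ADME assay on HEK293 cells (Homo sapiens) for cytotoxicity, read by luminescence, with a stated time of 72 h (on this read-out higher numbers stand for an effect only at larger amounts of compound and lower numbers for an effect already at smaller amounts), compound 3 `CCOC(=O)c1c(-c2cccc(Cl)c2)[nH]c2cc(OC)c(Cl)cc2c1=O` gives > 22000 nM, a limit of the assay and not a number. Compound 2 `CCOC(=O)c1c(-c2cccc(OC)c2)[nH]c2cc(OC)c(Cl)cc2c1=O` gives > 22000 nM, again a limit. Compound 1 `CCOC(=O)c1c(-c2cccc(Br)c2)[nH]c2cc(OC)ccc2c1=O`, which carries the 3-bromophenyl group, gives > 22000 nM, also a limit. All readings so far are of one kind: the limit of > 22000 nM in this assay, at which 3 of the 3 values shown sit. Compound 3 therefore has no numerical position, only a shared limit.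

The next compound is compound 4 `CCOC(=O)c1c(-c2cccc(Br)c2)[nH]c2cc(OC)c(Cl)cc2c1=O`. The change is bromo in place of chloro on an aromatic carbon, that is, 3-chlorophenyl to 3-bromophenyl. Within the data shown here, the one measured step that bears on it is a step that the two limits leave unreadable from compound 2 to compound 3, which gives no size to carry over. With no readable step and all three values at the limit, no step beyond the scatter is expected in this assay, and no direction can be assigned. The estimated step is a step that the limit leaves unreadable from compound 3 to compound 4. The expected value for compound 4 is 25000 nM, with an estimated range of 14000 nM to 44000 nM, and the most likely report is again a limit.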

Compound 4, half-maximal effective concentration: > 22000 nM
Compound 4 ended at the assay's limit; the forecaster's own chance of this, stated with the estimate: 85%; the middle value is on the limit's open side.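

The steps from compound 1, compound 2 and compound 3 to compound 4 cannot be read in this assay, as each pair rests on two limits: the limit of > 22000 nM in this assay, at which 4 of the 4 values shown sit.

The compounds shown leave open where any of them would reach a half-maximal effect in this assay, and so what size the change from 3-chlorophenyl to 3-bromophenyl has.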